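A few compounds are considered here, and "the series" means these few. Any claim that something is new, unique, unknown or untested is made for them only; others in the source may bear on it.

In a functional assay on HT-29 cells (Homo sapiens) for inhibition (on this read-out lower numbers stand for stronger inhibition and higher numbers for weaker inhibition), compound 1 (`CCCCCCCCCCCCCCCCCCOC[C@H](COP(=O)(O)O[C@@H]1[C@H](O)[C@@H](CO)[C@@H](O)[C@H](O)[C@@H]1O)OC`) gives 4500 nM, and compound 2 (`CCCCCCCCCCCCCCCCCCOC[C@H](COP(=O)(O)O[C@@H]1[C@H](O)[C@@H](CO)[C@@H](O)[C@H](O)[C@@H]1O)n1ccnc1`) gives 6500 nM, which places compound 2 within the scatter of compound 1. Compound 3 (`CCCCCCCCCCCCCCCCCCOC[C@H](COP(=O)(O)O[C@H]1[C@@H](O)[C@@H](O)[C@H](O)C[C@H]1O)n1ccnc1`) differs from compound 2 by a single change, hydrogen in place of hydroxymethyl on a saturated ring carbon. Within the data shown here, the only measured step, a 1.4-fold higher number from compound 1 to compound 2 (0.16 log units; within the scatter), puts 1H-imidazol-1-yl in place of methoxy on a saturated chain carbon, and it lies within the scatter. Among the measured compounds shown here, that step does not touch the ring carbon, and no measured pair tests the loss of hydroxymethyl, so the data favour no direction. No step beyond the scatter is therefore expected in this assay, though this expectation is loosely held. The expected step is a 1.1-fold lower number from compound 2 to compound 3 (0.03 log units; within the scatter). For compound 3 the estimated value is 6000 nM, within an expected range of 2500 nM to 15000 nM.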

Compound 3, half-maximal inhibitory concentration: 15000 nM
The estimate for compound 3 lay 2.5-fold (0.40 log units) below the measured number, within the range that was stated.
By their numbers in this assay, from the lowest: compounds 1 and 2 (each within the scatter of the next); then compound 3.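

In this assay, the hydroxymethyl on the saturated ring carbon turns out to count for more than the earlier chain change suggested: its replacement by hydrogen gives a 2.3-fold higher number from compound 2 to compound 3 (0.36 log units; beyond the scatter), whereas a 1.4-fold higher number from compound 1 to compound 2 (0.16 log units; within the scatter) did not separate the two compounds. This is the first step among these compounds that lies beyond the scatter, and it is modest in size and runs toward weaker inhibition, so the ring position responds to this change where the chain carbon did not respond to its own. Nothing at hand explains why removing this group raises the number.

Hydrogen and hydroxymethyl are the only groups compared at this ring carbon, so it remains open whether a methyl, an aminomethyl or a carboxylic acid there would stay close to compound 2 or follow compound 3. Also open, from the compounds shown here alone, is whether the same change would give a step of this size with methoxy rather than 1H-imidazol-1-yl on the chain carbon.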